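Acetyl in place of the carboxylic chain on the ring nitrogen

The source may report more compounds than this note shows. Statements on the series, on what has been measured and on what is new or still open speak of the compounds shown alone.

Among the measured compounds shown here, compound 3 `O=C(O)CCCn1c2ccc([N+](=O)[O-])cc2c(=O)n1Cc1ccccc1` sits at the top of the numbers so far: in an ADME assay on L929 cells (Mus musculus) for cytotoxicity, read by resazurin assay, with a stated time of 48 h (a higher number here means that more compound is tolerated, a lower number that less compound is tolerated), compound 3 gives > 256000 nM, which is a limit of the assay and not a number. Compound 2 `N#CCn1c2ccc([N+](=O)[O-])cc2c(=O)n1Cc1ccccc1` gives > 256000 nM in this assay, likewise a limit. Compound 1 `C=CCn1c2ccc([N+](=O)[O-])cc2c(=O)n1Cc1ccccc1` gives 192000 nM in this assay. the limit of > 256000 nM in this assay, at which 2 of the 3 values shown sit, frames the series: the measured steps run an at least 1.3-fold higher number from compound 1 to compound 2 (0.12 log units; that floor lies within the scatter), an at least 1.3-fold higher number from compound 1 to compound 3 (0.12 log units; that floor lies within the scatter) and a step that the two limits leave unreadable from compound 2 to compound 3, so nothing beyond the scatter is visible among the three.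

Compound 4 `CC(=O)n1c2ccc([N+](=O)[O-])cc2c(=O)n1Cc1ccccc1` differs from compound 3 by acetyl in place of 3-carboxypropyl on an aromatic nitrogen. For the measured compounds named here, no measured step touches an acyl group on the aromatic nitrogen; the measured steps all exchange groups on a saturated chain carbon bound to an aromatic nitrogen, and none of them moved this assay beyond its scatter, with two of the three compounds at the limit. The expectation for compound 4 is therefore a step of about an at least 1.1-fold lower number from compound 3 to compound 4 (0.04 log units; that floor lies within the scatter), that is no movement beyond the scatter, with a fair chance that this assay again reports only a limit. Compound 4 is estimated at 230000 nM in this assay, within a range from 100000 nM to 520000 nM.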

Compound 4, concentration lethal to 50% of the cells: > 256000 nM
Compound 4 ended at the assay's limit; the forecaster's own chance of this, stated with the estimate: 55%; middle value at least 1.1-fold (0.04 log units) from the limit.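

In this assay, among the compounds shown here, compound 4 gives > 256000 nM, which is a limit of the assay and not a number, and this is the first group on the aromatic nitrogen that is attached through a carbonyl and not through a saturated chain carbon. For the compounds shown here, the one step that can be read is an at least 1.3-fold higher number from compound 1 to compound 4 (0.12 log units; that floor lies within the scatter), and the steps that join two limits cannot be read. Exchanging 3-carboxypropyl for acetyl, with 3 heavy atoms in place of 6 and 0 hydrogen-bond donors in place of 1, therefore brings no value down from the limit, and the series now presses against the top of the read-out: the limit of > 256000 nM in this assay, at which 3 of the 4 values shown sit.

Going by these compounds alone, compound 1, with its allyl group, is the only compound here that gives an actual number, so the order among compound 2, compound 3 and compound 4 stays unknown. Still open, from the compounds shown here alone, is whether an amine, a benzoyl group or a longer alkyl chain on this nitrogen would give a number below the limit, and by how much it would lie beyond the scatter.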